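Ethyl to methoxy on the aryl ring: working notes

A few compounds are considered here, and "the series" means these few. Any claim that something is new, unique, unknown or untested is made for them only; others in the source may bear on it.

Measured compounds:
compound 1, `CC(C)n1ncc2c(C(=O)NCc3cn(-c4ccccc4)nn3)cccc21`; in a functional assay on MCF7 cells (Homo sapiens) for inhibition, read by MTT assay, with a stated time of 72 h (on this read-out higher numbers stand for weaker inhibition and lower numbers for stronger inhibition), compound 1 gives > 40000 nM.
compound 2, `CCc1ccc(-n2cc(CNC(=O)c3cccc4c3cnn4C(C)C)nn2)cc1`; in this assay compound 2 gives > 40000 nM.

The value of compound 1 in this assay is a limit of the assay, not a number. The value of compound 2 in this assay is likewise a limit. This is the situation described by the limit of > 40000 nM in this assay, at which 2 of the 2 values shown sit. Among the compounds with values here, the one step between measured compounds, a step that the two limits leave unreadable from compound 1 to compound 2, is therefore unreadable in size and direction.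

Compound 3, `COc1ccc(-n2cc(CNC(=O)c3cccc4c3cnn4C(C)C)nn2)cc1`, differs from compound 2 by methoxy in place of ethyl on an aromatic carbon. Within the data shown here, no measured step bears on this change with a readable size, so no step beyond the scatter can be expected in either direction; the best expectation is that compound 3 stays where compound 2 sits. Compound 3 is thus estimated at 60000 nM, in a range from 20000 nM to 200000 nM. The step this implies, a step that the limit leaves unreadable from compound 2 to compound 3, is an estimate only, and a further limit rather than a number is the most likely outcome for compound 3.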

Compound 3, half-maximal inhibitory concentration: > 40000 nM
Compound 3 was reported as a limit; the forecaster's own chance of this, stated with the estimate: 85%; the middle value is on the limit's open side.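

In this assay compound 3 gives > 40000 nM as a limit of the assay. Within the data shown here, no step among compound 1, compound 2 and compound 3 can be read, as all three values sit at one limit: the limit of > 40000 nM in this assay, at which 3 of the 3 values shown sit. The compounds shown leave open whether hydrogen, ethyl or methoxy on the aryl ring makes any difference to inhibition.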